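The compounds below may be only part of what the source reports. "The series", "measured", "known", "first", "only" and "open" are said of these compounds alone.

The measured compounds:
compound 1, `O=C(CCCCC(S)CCS)Nc1ccccc1`, which in a functional assay on KB cells (Homo sapiens) for inhibition, read by MTT assay, with a stated time of 24 h, tested at 1 ug/mL (a higher number here means more inhibition of growth at the concentration tested, a lower number less inhibition of growth), gives 11.6%;
compound 2, `O=C(CCCCC(S)CCS)Nc1ccc(Cl)cc1`, which in this assay gives 13.4%;
compound 3, `O=C(CCCCC(CCSC(=O)c1ccccc1)SC(=O)c1ccccc1)Nc1ccccc1`, which in this assay is reported only as "not active" (no number reported).

From compound 1 to compound 2 the change is chloro in place of hydrogen on an aromatic carbon. In this assay this gave a number 1.8 percentage points higher from compound 1 to compound 2 (within the scatter). The difference between the core of compound 1 and the core of compound 3 is not broken down here. Compound 4, `O=C(CCCCC(CCSC(=O)c1ccccc1)SC(=O)c1ccccc1)Nc1ccccc1Cl`, has not been measured; it differs from compound 3 by chloro in place of hydrogen on an aromatic carbon, the same kind of change as from compound 1 to compound 2, although the chloro here sits ortho to a large group where in compound 2 it sits para to a large group. Because the matching change gave a number 1.8 percentage points higher from compound 1 to compound 2 (within the scatter), a step of similarly small size from compound 3 to compound 4 is expected in this assay. Since compound 3 carries no number, compound 4 is estimated at 8% in this assay, expected between 0% and 20%.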

Compound 4, percent growth inhibition at one concentration: 3.05%
Beside the measured number, compound 4's estimate is 5 percentage points above it, and the stated range covers the measured number.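

Going by these compounds alone, compound 3 is reported in this assay only as not active, without a number, so no step from compound 3 to compound 4 can be read. The compounds shown leave open whether chloro in place of hydrogen acts alike on the core of compound 1 and the core of compound 3, and whether its place on the ring matters. Nothing given here offers an explanation for the result.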